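Compound 4: returning from the urea side to an aryl carbonyl

A few compounds are considered here, and "the series" means these few. Any claim that something is new, unique, unknown or untested is made for them only; others in the source may bear on it.

- compound 1 `COc1cc(-c2nn(-c3cccc(NC(=O)c4cccc(C(F)(F)F)c4)c3)cc2-c2ccncc2)ccc1Cl` gives 10800 nM
- compound 2 `COc1cc(-c2nn(-c3cccc(NC(=O)Nc4ccc(Cl)c(Cl)c4)c3)cc2-c2ccncc2)ccc1Cl` gives 1690 nM
- compound 3 `O=C(Nc1cccc(-n2cc(-c3ccncc3)c(-c3ccc(Cl)c(O)c3)n2)c1)Nc1ccc(Cl)c(Cl)c1` gives 2890 nM

In a functional assay on NCI-H322M cells (Homo sapiens) for inhibition, read by sulforhodamine B assay, with a stated time of 48 h (a higher number here means a weaker inhibitor of growth, a lower number a stronger inhibitor of growth), compound 2 stands at the low end of the three numbers. Hydrogen in place of methyl on its oxygen gives a 1.7-fold higher number from compound 2 to compound 3 (0.23 log units; within the scatter), so that change offers little guidance here. Compound 4 `COc1cc(-c2nn(-c3cccc(NC(=O)c4ccc(Cl)c(C(F)(F)F)c4)c3)cc2-c2ccncc2)ccc1Cl` carries 4-chloro-3-(trifluoromethyl)phenyl in place of (3,4-dichlorophenyl)amino on a carbonyl carbon. The closest measured precedent is the change of (3,4-dichlorophenyl)amino for 3-(trifluoromethyl)phenyl on a carbonyl carbon, with a 6.4-fold lower number from compound 1 to compound 2 (0.81 log units; beyond the scatter). Among the measured compounds shown here, compound 4 runs in the opposite direction, although its added chlorine leaves that precedent inexact, and no measured step isolates the chlorine. A higher number is therefore expected, with an estimated 3.0-fold higher number from compound 2 to compound 4 (0.47 log units; beyond the scatter). The estimate for compound 4 is 5000 nM, within a range of 2000 nM to 12000 nM.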

Compound 4, concentration for 50% growth inhibition: 12800 nM
Compound 4: middle estimate off by 2.6-fold (0.41 log units), on the low side; measured number outside the range, above it.
By their numbers in this assay, from the lowest: compounds 2 and 3 (each within the scatter of the next); then compounds 1 and 4 (each within the scatter of the next).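

With chloro in place of hydrogen on an aromatic carbon, the number is a 1.2-fold higher number from compound 1 to compound 4 (0.07 log units; within the scatter) in this assay, so this chlorine gives no measurable gain or loss. Replacing the urea-linked (3,4-dichlorophenyl)amino with 4-chloro-3-(trifluoromethyl)phenyl on the carbonyl carbon gives a 7.6-fold higher number from compound 2 to compound 4 (0.88 log units; beyond the scatter), so the urea compound 2 keeps its advantage over this chlorinated aryl carbonyl too. No available evidence explains this gap. Still open, on these data alone, is whether a urea carrying the 4-chloro-3-(trifluoromethyl)phenyl ring would match compound 2, and whether a morpholine or a carboxylic acid on that ring would shift the number.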